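Swapping Methoxy for Chloro on the Fused Core

The compounds below may be only part of what the source reports. "The series", "measured", "known", "first", "only" and "open" are said of these compounds alone.

Compound 1 `Cc1onc(-c2ccc(Cl)cc2Cl)c1C(=O)/N=c1/nc2nc(Cl)cc(C)n2s1`: 32.8%
Compound 2 `COc1cc(OC)n2s/c(=N\C(=O)c3c(-c4ccc(Cl)cc4Cl)noc3C)nc2n1`: 53.8%

Of the compounds shown here, two have been tested in a functional assay on the whole organism for inhibition, with Digitaria ciliaris as the target, with a stated time of 72 h, tested at 10 mg/L; a higher number here means more inhibition of growth at the concentration tested, a lower number less inhibition of growth. Compound 2 gives 53.8%, the higher of the two numbers, while compound 1 lies a good way lower, beyond the usual scatter. Compound 3 `COc1cc(Cl)nc2n/c(=N/C(=O)c3c(-c4ccc(Cl)cc4Cl)noc3C)sn12` is not yet measured; it differs from compound 2 by chloro in place of methoxy on an aromatic carbon. Among the compounds with values here, no step between measured compounds is available for guidance. Compound 1 gives 32.8% and also carries a chloro group on the shared core, so a moderate downward step is expected, a number 11.8 percentage points lower from compound 2 to compound 3 (beyond the scatter). Compound 3 is estimated at 42%, between 25% and 60%.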

Compound 3, percent growth inhibition at one concentration: 16.5%
Compound 3: the middle estimate sits 25.5 percentage points above what was measured; measured number outside the range, below it.
By their numbers in this assay, from the lowest: compound 3; then compound 1; then compound 2.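

In this assay, a single change of methoxy to chloro on this aromatic carbon gives a number 37.3 percentage points lower from compound 2 to compound 3 (beyond the scatter), so this one position alone can move growth inhibition by a large amount. Methoxy does not raise the number everywhere, though: with chloro present, methoxy in place of methyl gives a number 16.3 percentage points lower from compound 1 to compound 3 (beyond the scatter), and compound 1 therefore goes against any simple rule that more methoxy means more inhibition. Nothing available explains why either number falls.

The compounds shown leave open how an amine or an ethoxy group would behave at this position. They also leave open whether the step from methoxy to chloro would be as large on a core without a second methoxy group.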